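This account rests on a few compounds, and the source may have more. Where it says the series, first, only, none or still open, it means among the compounds named here.

Measured so far:
compound 1, `Cc1ccc(C2C(C#N)=C(N)N(c3ccc(S(N)(=O)=O)cc3)C3=C2C(=O)CCC3)cc1`: 30%
compound 2, `COc1ccc(C2C(C#N)=C(N)N(c3ccc(S(N)(=O)=O)cc3)C3=C2C(=O)CCC3)cc1`: 50%
compound 3, `N#CC1=C(N)N(c2ccc(S(N)(=O)=O)cc2)C2=C(C(=O)CCC2)C1c1cccc([N+](=O)[O-])c1`: 50%

All three numbers come from a functional assay on Ehrlich cells (Mus musculus) for antiproliferative activity, read by trypan blue exclusion, with a stated time of 2 h, tested at 25 ug/mL; on this read-out higher numbers stand for a stronger effect at the one concentration tested and lower numbers for a weaker effect. Compound 1 stands lowest of the three; its nearest neighbour is compound 2, reached by a number 20 percentage points higher from compound 1 to compound 2 (beyond the scatter), and compound 3 lies just as far away, by a number 20 percentage points higher from compound 1 to compound 3 (beyond the scatter). Between the other two there is no change at the digits printed from compound 2 to compound 3 (within the scatter).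

Compound 4, `COc1ccc2ccccc2c1C1C(C#N)=C(N)N(c2ccc(S(N)(=O)=O)cc2)C2=C1C(=O)CCC2`, has not yet been measured in this assay. It differs from compound 1 in one place: 2-methoxynaphthalen-1-yl in place of 4-methylphenyl on a saturated ring carbon. Within the data shown here, two measured steps bear on this change. The step from compound 1 to compound 2 put a methoxy in place of a methyl on an aromatic carbon, and the step from compound 1 to compound 3 exchanged the whole 4-methylphenyl for a different aryl group; each raised the number modestly and beyond the scatter. Among the measured compounds shown here, the group entering in compound 4 brings a methoxy and a second aromatic ring, so a rise of similar size is expected, a number 15 percentage points higher from compound 1 to compound 4 (beyond the scatter), although the extra ring has no precedent among the measured compounds. Compound 4 is therefore estimated at 45% in this assay, with a range from 25% to 65%.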

Compound 4, a percentage reported as activity, at one concentration (the size of the read-out at that concentration, not a potency): 62%
For compound 4 the middle estimate is 17 percentage points below the measured one; measured number inside the range.
By their numbers in this assay, from the lowest: compound 1; then compounds 2 and 3 (each within the scatter of the next); then compound 4.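

In this assay, the saturated ring carbon next to the ring atom bearing the cyano group accepts a group with two aromatic rings, and activity still rises: 2-methoxynaphthalen-1-yl in place of 4-methylphenyl gives a number 32 percentage points higher from compound 1 to compound 4 (beyond the scatter), a large step. The 4-methoxyphenyl and 3-nitrophenyl groups could not be told apart, but this group stands clear of both, with a number 12 percentage points higher from compound 2 to compound 4 (beyond the scatter) and a number 12 percentage points higher from compound 3 to compound 4 (beyond the scatter), making compound 4 the most active of the four at the one concentration tested. Nothing available explains this gain.

The methoxy and the second aromatic ring enter together, so the compounds shown leave open how much of the rise belongs to each; a naphthalen-1-yl group without the methoxy would separate them. Also open, as far as these compounds go, is how an amine or a carboxylic acid on the aromatic ring at this carbon would read out.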